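Cyano in Place of Methoxy: An Expected Value

The compounds below may be only part of what the source reports. "The series", "measured", "known", "first", "only" and "open" are said of these compounds alone.

Compound 2 `COc1cc(N2C[C@H]3CCNC[C@H]32)cnc1Br` is the mirror image of compound 1 `COc1cc(N2C[C@@H]3CCNC[C@@H]32)cnc1Br`. In a functional assay on HEK293 cells for agonist activity at Neuronal acetylcholine receptor; alpha3/beta4 (Homo sapiens), read by FLIPR (a lower number here means that less compound is needed, a higher number that more compound is needed for the effect), compound 1 gives 2980 nM, and compound 2 gives 202 nM, the lowest of the two numbers; the step of a 15-fold lower number from compound 1 to compound 2 (1.17 log units; beyond the scatter) rests on (the fact that compounds 1 and 2 differ only in the configuration as drawn). Compound 3 `N#Cc1cc(N2C[C@H]3CCNC[C@H]32)cnc1Br` differs from compound 2 by cyano in place of methoxy on an aromatic carbon. Among the compounds with values here, no measured step covers this exchange; the only step known, from compound 1 to compound 2, concerns configuration alone. The account therefore expects for compound 3 in this assay a change no larger than the scatter, a 1.5-fold higher number from compound 2 to compound 3 (0.17 log units; within the scatter). The estimate for compound 3 is 300 nM, within 60 nM to 1500 nM.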

Compound 3, half-maximal effective concentration: 238 nM
For compound 3 the middle estimate is 1.3-fold (0.10 log units) above the measured one, and the stated range covers the measured number.
By their numbers in this assay, from the lowest: compounds 2 and 3 (each within the scatter of the next); then compound 1.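

In this assay, cyano in place of methoxy on this aromatic carbon, ortho to a bromo group, gives a 1.2-fold higher number from compound 2 to compound 3 (0.07 log units; within the scatter) and so stays within the scatter. The earlier compounds shown here spoke only to configuration; this pair shows that, with the configuration of compound 2 held, these two groups read alike at this position. Nothing at hand accounts for that likeness.

Open, from the compounds shown here alone, is whether an amine or a carboxylic acid at this position would read the same way. Also open, going by these compounds, is how cyano behaves in the configuration of compound 1.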